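Lengthening the ester arm on the shared core

A few compounds are considered here, and "the series" means these few. Any claim that something is new, unique, unknown or untested is made for them only; others in the source may bear on it.

Compound 1 `COC(=O)Cn1c(=O)c(C)cn([C@@H]2O[C@H](CO[Si](C)(C)C(C)(C)C)[C@@]3(OS(=O)(=O)C=C3N)[C@H]2O[Si](C)(C)C(C)(C)C)c1=O`: in a functional assay on CCRF-CEM cells (Homo sapiens) (on this read-out higher numbers stand for lower toxicity in this test and lower numbers for higher toxicity in this test), compound 1 gives a limit of the assay, > 152000 nM.
Compound 2 `Cc1cn([C@@H]2O[C@H](CO[Si](C)(C)C(C)(C)C)[C@@]3(OS(=O)(=O)C=C3N)[C@H]2O[Si](C)(C)C(C)(C)C)c(=O)n(CC(=O)O)c1=O`: in this assay compound 2 gives 152000 nM.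
Compound 3 `Cc1cn([C@@H]2O[C@H](CO[Si](C)(C)C(C)(C)C)[C@@]3(OS(=O)(=O)C=C3N)[C@H]2O[Si](C)(C)C(C)(C)C)c(=O)n(CCO)c1=O`: in this assay compound 3 gives 11300 nM.

Compound 1 stands at the edge of what this assay can report: its result is a limit and not a number, and it is the only one of the three that sits there (the limit of > 152000 nM in this assay, at which 1 of the 3 values shown sits). The measured steps away from it give a number no higher from compound 1 to compound 2 (the limit leaves the size open) and an at least 13-fold lower number from compound 1 to compound 3 (1.12 log units; beyond the scatter), and between the two measured neighbours a 13-fold lower number from compound 2 to compound 3 (1.13 log units; beyond the scatter).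

Compound 4 `CCOC(=O)CCCCCn1c(=O)c(C)cn([C@@H]2O[C@H](CO[Si](C)(C)C(C)(C)C)[C@@]3(OS(=O)(=O)C=C3N)[C@H]2O[Si](C)(C)C(C)(C)C)c1=O` has not been measured. (4-(ethoxycarbonyl)butyl in place of methoxycarbonyl on a saturated chain carbon bound to an aromatic nitrogen). Among the compounds with values here, none of the measured steps covers this change: compound 2 and compound 3 replaced the methoxycarbonyl with carboxy or hydroxymethyl, whereas compound 4 keeps an ester of the same kind, only as ethoxycarbonyl at the end of a longer chain. The large drop seen in compound 3 came with hydroxymethyl, which compound 4 does not carry. Compound 4 is therefore expected to stay near compound 1, at an estimated 130000 nM with a range of 35000 nM to 450000 nM, which means an expected step of an at least 1.1-fold lower number from compound 1 to compound 4 (0.06 log units; that floor lies within the scatter), and a result that again is only a limit is quite possible.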

Compound 4, half-maximal cytotoxic concentration: 40600 nM
Compound 4: the middle estimate sits 3.2-fold (0.51 log units) above what was measured; measured number inside the range.
By their numbers in this assay, from the lowest: compound 3; then compound 4; then compound 2.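

Keeping an ester on this arm does not keep the result at the top of the scale. In this assay, replacing methoxycarbonyl with 4-(ethoxycarbonyl)butyl on a saturated chain carbon bound to an aromatic nitrogen gives an at least 3.7-fold lower number from compound 1 to compound 4 (0.57 log units; beyond the scatter), although both groups carry the same counts of hydrogen-bond donors and acceptors and no net charge, and the new group has more carbon atoms. The measured compounds now occupy three separate levels at this position, with compound 4 in the middle: the steps are a 3.7-fold lower number from compound 2 to compound 4 (0.57 log units; beyond the scatter) and a 3.6-fold higher number from compound 3 to compound 4 (0.56 log units; beyond the scatter). Compound 1 still gives only a limit of the assay, so its step shows a lowest size and no exact one: the limit of > 152000 nM in this assay, at which 1 of the 4 values shown sits.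

Chain length and the kind of ester change together in compound 4. The data do not separate these two changes, and a methyl ester on the same longer chain would separate them. Also open, from the compounds shown here alone, is whether an amine or a carboxylic acid at the end of that longer chain would give a number nearer that of compound 3 or compound 2.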